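Cytotoxicity of the shared core with varied benzylic groups

This account rests on a few compounds, and the source may have more. Where it says the series, first, only, none or still open, it means among the compounds named here.

Among the measured compounds shown here, compound 1 `O=C1N(Cc2cccc(Cl)c2)c2cccn2S(=O)(=O)N1Cc1ccccc1` is the only member with a number: in an ADME assay on MT4 cells (Homo sapiens) for cytotoxicity, read by MTT assay, with a stated time of 5 days (on this read-out lower numbers stand for higher toxicity in this test and higher numbers for lower toxicity in this test), compound 1 gives 196000 nM. Compound 2 `O=C1N(C/C=C/c2ccccc2)c2cccn2S(=O)(=O)N1Cc1ccccc1` shows only a limit of this assay, > 318000 nM. For the measured compounds named here, compound 2 therefore stands at the limit of > 318000 nM in this assay, at which 1 of the 2 values shown sits, and the one comparison at hand is an at least 1.6-fold higher number from compound 1 to compound 2 (0.21 log units; that floor lies within the scatter). Compound 3 `O=C1N(Cc2ccccc2Cl)c2cccn2S(=O)(=O)N1Cc1ccccc1` differs from compound 2 by 2-chlorophenyl in place of 2-phenylethenyl on a saturated chain carbon bound to an amide-type nitrogen in a ring. That single measured step bears on this change, and its floor lies within the scatter, so no movement beyond the scatter is expected. For compound 3 the estimate is 250000 nM, in the range 120000 nM to 500000 nM. The expected step is an at least 1.2-fold lower number from compound 2 to compound 3 (0.10 log units; that floor lies within the scatter).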

Compound 3, half-maximal cytotoxic concentration: > 291000 nM
Compound 3 gave a limit, no number; the forecaster's own chance of this, stated with the estimate: 40%; at least 1.1-fold (0.06 log units) between middle value and limit.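

In this assay the swap of 3-chlorophenyl for 2-chlorophenyl gives an at least 1.4-fold higher number from compound 1 to compound 3 (0.17 log units; that floor lies within the scatter) on this saturated chain carbon, so this change shows no movement beyond the scatter. Compound 3 gives only a limit of the assay, not a number, and this adds a chlorine-bearing group at this place that ends at a limit, as 2-phenylethenyl does in compound 2. The step between compound 2 and compound 3 cannot be read. On these data alone, whether an amine or a carboxylic acid at this place would move the read-out beyond the scatter stays open, as do actual numbers for compound 2 and compound 3.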